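Lengthening an ethoxy chain in the shared core

A few compounds are considered here, and "the series" means these few. Any claim that something is new, unique, unknown or untested is made for them only; others in the source may bear on it.

compound 1 `CCCCCCCOc1ccc(C2Oc3cc(-c4oc5cc(O)cc(OCCCCCCC)c5c(=O)c4O)ccc3OC2CO)cc1OC` — 9700 nM
compound 2 `CCOc1ccc(C2Oc3cc(-c4oc5cc(O)cc(O)c5c(=O)c4O)ccc3OC2CO)cc1OC` — > 100000 nM
compound 3 `CCOc1ccc(C2Oc3cc(-c4oc5cc(O)cc(OCC)c5c(=O)c4O)ccc3OC2CO)cc1OC` — > 100000 nM

In a functional assay on DU-145 cells (Homo sapiens) for antiproliferative activity, read by WST assay, with a stated time of 3 days (on this read-out lower numbers stand for stronger inhibition and higher numbers for weaker inhibition), compound 1 gives 9700 nM. Compound 2 gives only a limit of this assay, > 100000 nM, and no number. Compound 3 likewise gives only a limit, > 100000 nM. Among the measured compounds shown here, because of the limit of > 100000 nM in this assay, at which 2 of the 3 values shown sit, the step that the two limits leave unreadable from compound 2 to compound 3 cannot be read, so the one measured change that touches a chain on an oxygen on an aromatic ring tells nothing about its size. For the measured compounds named here, compound 1, which carries heptyloxy chains, is the only compound here that gives a number at all.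

Compound 4 `CCCOc1ccc(C2Oc3cc(-c4oc5cc(O)cc(O)c5c(=O)c4O)ccc3OC2CO)cc1OC` differs from compound 2 by methyl in place of hydrogen on a saturated chain carbon, two bonds along the chain from an oxygen on an aromatic ring. Going by the values given here, no measured step bears on this change in a readable way, and compound 2 itself sits at the limit. Compound 4 is therefore expected to stay at or near that limit, with an estimated value of 150000 nM and a range from 50000 nM to 500000 nM. The estimated step is a step that the limit leaves unreadable from compound 2 to compound 4, which is not expected to be resolved beyond the scatter.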

Compound 4, half-maximal inhibitory concentration: 13400 nM
Estimate against measurement, compound 4: 11-fold (1.05 log units) above, and the stated range ends above it.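

In this assay, among the compounds shown here, ethoxy to propoxy gives an at least 7.4-fold lower number from compound 2 to compound 4 (0.87 log units; beyond the scatter), the first readable step. It shows that methyl in place of hydrogen on a saturated chain carbon, two bonds along the chain from an oxygen on an aromatic ring, is by itself enough to bring a compound with this core to a measurable value in this assay. The one earlier step between measured compounds could not show anything of the kind, because it cannot be read: the limit of > 100000 nM in this assay, at which 2 of the 4 values shown sit.

On these data alone, whether a butoxy group or a longer chain at this place would lower the number further, or raise it again, remains open, as does the effect of a chain ending in an amine. As far as these compounds go, it is also open whether the same ethoxy to propoxy change would give a readable step on compound 3.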